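The compounds below may be only part of what the source reports. "The series", "measured", "known", "first", "only" and "open" are said of these compounds alone.

Compound 1, `CCC(COc1cccc(F)c1)OC(=O)NCc1ccccc1`, in an assay for inhibition of zeta-carotene desaturase, chloroplastic/chromoplastic (Capsicum annuum), using a Dixon plot, with a stated time of 8 h (a higher number here means a weaker inhibitor, a lower number a stronger inhibitor), gives > 100000 nM, which is a limit of the assay and not a number.
Compound 2, `CCC(COc1cccc(C(C)C)c1)OC(=O)NCc1ccccc1`, in this assay gives > 100000 nM, again a limit.
Compound 3, `CCC(COc1cccc(C(=O)O)c1)OC(=O)NCc1ccccc1`, in this assay gives > 100000 nM, also a limit.

Compound 1 therefore stands only at a limit in this assay, and the two further values shown are limits as well. The step that the two limits leave unreadable from compound 1 to compound 2 cannot be read, nor can a step that the two limits leave unreadable from compound 1 to compound 3 or a step that the two limits leave unreadable from compound 2 to compound 3, because every value sits at the same limit (the limit of > 100000 nM in this assay, at which 3 of the 3 values shown sit).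

Compound 4, `CCC(COc1cc(Cl)cc(Cl)c1)OC(=O)NCc1ccccc1`, differs from compound 1 as follows: 3,5-dichlorophenyl in place of 3-fluorophenyl on an oxygen on a saturated carbon. Going by the values given here, the steps that bear on this change are those from compound 1 to compound 2 and from compound 1 to compound 3, which alter the same aromatic ring, but neither gives a readable size. Among the compounds with values here, no measured step shows any substituent on that ring producing a number within the range of this assay.

The step from compound 1 to compound 4 is estimated as a step that the limit leaves unreadable from compound 1 to compound 4, with no readable direction to build on. Compound 4 is expected to give about 150000 nM in this assay, within a range from 30000 nM to 1000000 nM, and most probably only a limit again.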

Compound 4, half-maximal inhibitory concentration: > 100000 nM
Compound 4: no number, only a limit; the forecaster's own chance of this, stated with the estimate: 85%; the middle value is on the limit's open side.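

No new step can be read between compound 1 and compound 4, because both stand at the same limit of the assay and neither gives a number: the limit of > 100000 nM in this assay, at which 4 of the 4 values shown sit.

The compounds shown leave open which substituents on the aromatic ring, if any, would give a number rather than a limit in this assay.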